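The compounds below may be only part of what the source reports. "The series", "measured", "known", "first", "only" and "open" are said of these compounds alone.

In a functional assay on the whole organism with Mus musculus as the target (a higher number here means that more compound is needed for the effect, a lower number that less compound is needed), compound 1 `CNC(=O)/C(C)=C/c1cccc(C(F)(F)F)c1` gives 68.8 mg/kg. Compound 2 `O=C1CCC(O)(c2cccc(C(F)(F)F)c2)N1` yields no number, only a limit of the assay, > 200 mg/kg. The two structures differ in more than one place, so they reveal nothing about the effect of any single change.

The next structure, compound 3 `CCCCN1C(=O)CCC1(O)c1cccc(C(F)(F)F)c1`, comes from compound 2 through one change, butyl in place of hydrogen on an amide-type nitrogen in a ring. Within the data shown here, no measured pair shows what this change does in this assay, so any forecast is uncertain. A moderate step beyond the scatter, towards less compound needed, is expected, and another limit remains possible. Among the measured compounds shown here, the forecast leans on compound 1, whose 68.8 mg/kg is the only true number available. The expected step is an at least 1.6-fold lower number from compound 2 to compound 3 (0.22 log units; that floor lies within the scatter). For compound 3, the estimated dose is 120 mg/kg, with an expected range of 50 mg/kg to 300 mg/kg.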

Compound 3, dose for half-maximal effect: 183 mg/kg
Estimate against measurement, compound 3: 1.5-fold (0.18 log units) below; the measured number falls inside the stated range.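

With butyl in place of hydrogen on the amide-type nitrogen, this assay shows an at least 1.0-fold lower number from compound 2 to compound 3 (0.03 log units; that floor lies within the scatter). On these data alone, the figure for compound 2 is a limit of the assay and not a true number, so the real size of this step is unknown: the limit of > 200 mg/kg in this assay, at which 1 of the 3 values shown sits. The change does show that this nitrogen can carry butyl and still give a measurable dose, yet the printed floor of the step stays within the usual scatter and so does not by itself establish a real gain.

As far as these compounds go, what a methyl group, a longer chain such as octyl, or a butyl chain ending in an amine would do at this nitrogen remains open. Whether any effect depends on the chain's length or on the atoms it carries also remains open, since butyl is the only group shown at this position.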